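The source may report more compounds than this note shows. Statements on the series, on what has been measured and on what is new or still open speak of the compounds shown alone.

Two compounds of the series carry a measurement in a functional assay on A549 cells (Homo sapiens), read by MTT assay, with a stated time of 72 h (a lower number here means a stronger inhibitor, a higher number a weaker inhibitor), so far. Compound 1 `C#Cc1cn([C@@H]2O[C@H](CO)[C@@H](O)[C@H]2O)c2ncnc(C)c12` gives 19200 nM in this assay. Compound 2 `Cc1nc(N)c2c(-c3cccs3)cn([C@@H]3O[C@H](CO)[C@@H](O)[C@H]3O)c2n1` reaches only the limit of > 20000 nM in this assay, so for it no number is known, only that it lies at the limit. Compound 2 thus stands at the limit of > 20000 nM in this assay, at which 1 of the 2 values shown sits. Compound 3 `Cc1nc(N)c2c(-c3ccoc3)cn([C@@H]3O[C@H](CO)[C@@H](O)[C@H]3O)c2n1` is the next analogue and carries furan-3-yl in place of thiophen-2-yl on an aromatic carbon. Within the data shown here, no step between measured compounds is available for this change, and the values shown for compound 1 and compound 2 sit close together near the top of the measured range. A step of only a step that the limit leaves unreadable from compound 2 to compound 3 is expected in this assay, none beyond the usual scatter. Compound 3 is therefore estimated to give 25000 nM in this assay, with a range of 8000 nM to 80000 nM, and this assay may again report only a limit.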

Compound 3, half-maximal inhibitory concentration: > 20000 nM
Compound 3 gave a limit, no number; the forecaster's own chance of this, stated with the estimate: 65%; the middle value does not contradict the limit.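

In this assay, among these compounds, compound 2 and compound 3 both give only a limit, not a number, and no step between them can be read: the limit of > 20000 nM in this assay, at which 2 of the 3 values shown sit. The compounds shown leave open whether furan-3-yl in place of thiophen-2-yl changes the result in this assay at all.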